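Butyl to pentyl on a quinazoline-free named core: one carbon more

This account rests on a few compounds, and the source may have more. Where it says the series, first, only, none or still open, it means among the compounds named here.

Measured compounds:
Compound 1, `CCCCNc1nc(NCc2ccco2)c2ccccc2n1`: 2940 nM
Compound 2, `CCCCNc1nc(NCc2ccco2)c2cccc(F)c2n1`: "not determined" (no result reported)

Within the data shown here, compound 1 is the only member of this small set with a number. In a functional assay on HT-29 cells (Homo sapiens) for cytotoxicity, read by MTT assay, with a stated time of 2 days (on this read-out higher numbers stand for weaker inhibition and lower numbers for stronger inhibition), compound 1 gives 2940 nM, which places it in the low micromolar region of this read-out. Compound 2 carries the same side chains as compound 1 with a fluorine added to the shared core, but for compound 2 the entry reads "not determined" (no result reported), so it offers nothing to compare against.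

Compound 3, `CCCCCNc1nc(NCc2ccco2)c2ccccc2n1`, is not yet measured. It differs from compound 1 by methyl in place of hydrogen on a saturated chain carbon, four bonds along the chain from a nitrogen on an aromatic ring; the butyl chain on one of the aromatic nitrogens becomes a pentyl chain, the rest of the molecule unchanged. Among the measured compounds shown here, no step between two measured compounds is available to show how chain length moves this read-out, so the expectation rests on the size of the change alone: one methyl added at the end of the chain. The step from compound 1 to compound 3 is expected to be a 1.2-fold lower number from compound 1 to compound 3 (0.07 log units; within the scatter), that is, no shift beyond the usual scatter. Compound 3 is therefore estimated at 2500 nM, within a range of 1000 nM to 6500 nM.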

Compound 3, half-maximal inhibitory concentration: 6730 nM
Estimate against measurement, compound 3: 2.7-fold (0.43 log units) below; the whole stated range lies below it.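

Putting methyl in place of hydrogen on a saturated chain carbon, four bonds along the chain from a nitrogen on an aromatic ring, turns the butyl chain into a pentyl chain and gives a 2.3-fold higher number from compound 1 to compound 3 (0.36 log units; beyond the scatter) in this assay. On this read-out a higher number means weaker inhibition, so this pair gives the first sign that the end of this chain is not indifferent to even a small addition: the step is modest, but it lies beyond the usual scatter. Nothing shown here explains why the number moves in this direction.

As far as these compounds go, a single step gives a direction for this one pair, not a trend along the chain, so it remains open whether a hexyl chain would continue the rise or a propyl chain would reverse it. Also open, from the compounds shown here alone, is how the read-out would respond to a branched isopentyl chain, or to a chain of similar length ending in an amine or a carboxylic acid.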